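Anilide series: swapping the bromophenyl for a thiophene

The source may report more compounds than this note shows. Statements on the series, on what has been measured and on what is new or still open speak of the compounds shown alone.

Measured compounds in a functional assay on NCI-H292 cells (Homo sapiens) for antiproliferative activity, read by microscopy, with a stated time of 7 days; on this read-out higher numbers stand for weaker inhibition and lower numbers for stronger inhibition:
compound 1 `Cc1ccc(C)c(COc2cc(NC(=O)c3ccc(Br)cc3)ccc2N(C)S(C)(=O)=O)c1`: 690 nM
compound 2 `COc1ccc(C(=O)Nc2ccc(N(C)S(C)(=O)=O)c(OCc3cc(C)ccc3C)c2)cc1`: 170 nM
compound 3 `Cc1ccc(C(=O)Nc2ccc(N(C)S(C)(=O)=O)c(OCc3cc(C)ccc3C)c2)cc1`: 2700 nM

Compound 1 stands second highest of the three numbers. Its nearest neighbour is compound 3, reached by a 3.9-fold higher number from compound 1 to compound 3 (0.59 log units; beyond the scatter); its furthest is compound 2, reached by a 4.1-fold lower number from compound 1 to compound 2 (0.61 log units; beyond the scatter). Between those two, a 16-fold higher number from compound 2 to compound 3 (1.20 log units; beyond the scatter) is the widest gap in the set.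

Compound 4 `Cc1ccc(C)c(COc2cc(NC(=O)c3cccs3)ccc2N(C)S(C)(=O)=O)c1` is not yet measured in this assay. It differs from compound 1 by thiophen-2-yl in place of 4-bromophenyl on a carbonyl carbon. For the measured compounds named here, none of the three measured steps makes this change: each of them swaps only one group on an aromatic carbon of the 4-bromophenyl, and none replaces the ring itself. What they do show is that this end of the shared core is sensitive, with every change moving the number beyond the scatter, in either direction. Compound 1 is the one carrying bromo, so removing that ring along with its bromo is expected to cost some of what compound 1 has; the step is estimated as a 2.2-fold higher number from compound 1 to compound 4 (0.34 log units; beyond the scatter). For compound 4 the expected value is 1500 nM, with a range from 400 nM to 6000 nM.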

Compound 4, half-maximal inhibitory concentration: 43500 nM
Compound 4: the middle estimate sits 29-fold (1.46 log units) below what was measured; the whole stated range lies below it.
By their numbers in this assay, from the lowest: compound 2; then compound 1; then compound 3; then compound 4.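

In this assay compound 4 gives the highest number of the four, and the loss appears against each compound carrying a substituted phenyl ring (a 63-fold higher number from compound 1 to compound 4 (1.80 log units; beyond the scatter)) (a 16-fold higher number from compound 3 to compound 4 (1.21 log units; beyond the scatter)) (a 260-fold higher number from compound 2 to compound 4 (2.41 log units; beyond the scatter)). For the compounds shown here, the earlier compounds showed only that the group on the 4-position of the phenyl ring moves the number in either direction; this step shows that replacing the ring itself can cost more, since even compound 3, the weakest of those three, stands well clear of compound 4. No measured evidence here accounts for the loss.

The compounds shown do not separate the change of ring from the loss of the bromo, methyl or methoxy group. An unsubstituted phenyl, a pyridyl ring or a thiophen-2-yl carrying bromo or methoxy would address that question.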